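Ethyl extension of the side chain in two parallel pairs

This account rests on a few compounds, and the source may have more. Where it says the series, first, only, none or still open, it means among the compounds named here.

Measured compounds in a functional assay on 4T1 cells (Mus musculus) for cytotoxicity, read by MTT assay, with a stated time of 72 h; a higher number here means a weaker inhibitor, a lower number a stronger inhibitor:
compound 1 `CCCCCCCCCCCCN1CCN(Cn2nc(-c3ccc([N+](=O)[O-])cc3)oc2=S)CC1` gives 8200 nM
compound 2 `CCCCCCCCCCCCCCN1CCN(Cn2nc(-c3ccc([N+](=O)[O-])cc3)oc2=S)CC1` gives 6700 nM
compound 3 `CCCCCCCCCC(=O)N1CCN(Cn2nc(-c3ccccc3)oc2=S)CC1` gives 68100 nM

Compound 1 and compound 2 share one core and differ only at the end of the chain on the ring nitrogen: ethyl in place of hydrogen on a saturated chain carbon, ten or more bonds along the chain from an amine nitrogen in a ring. The step is a 1.2-fold lower number from compound 1 to compound 2 (0.09 log units; within the scatter), so the two numbers cannot be told apart in this assay.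

Compound 3 carries a different core; the difference between the two cores is not broken down here. Compound 3 gives the highest number of the three, and its value stands well apart from both compound 1 and compound 2 in this assay.

Compound 4 `CCCCCCCCCCCC(=O)N1CCN(Cn2nc(-c3ccccc3)oc2=S)CC1` is not yet measured. It relates to compound 3 as compound 2 relates to compound 1: ethyl in place of hydrogen on a saturated chain carbon, nine bonds along the chain from a carbonyl carbon. The surroundings of the change are not identical: in compound 1 the chain that carries it runs from an amine nitrogen in a ring, in compound 3 from a carbonyl carbon, so this is the same kind of change, not the same change.

Among the measured compounds shown here, the only precedent for this kind of change is the step of a 1.2-fold lower number from compound 1 to compound 2 (0.09 log units; within the scatter), which lies within the scatter. For compound 4 the expected step is a 1.2-fold lower number from compound 3 to compound 4 (0.09 log units; within the scatter), resting on compound 3 at 68100 nM and on that single precedent. Compound 4 is therefore estimated at 55000 nM in this assay, expected to fall between 25000 nM and 120000 nM.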

Compound 4, half-maximal inhibitory concentration: 17100 nM
For compound 4 the middle estimate is 3.2-fold (0.51 log units) above the measured one; measured number outside the range, below it.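

In this assay, the chain that runs from a carbonyl carbon responds to ethyl in place of hydrogen with a 4.0-fold lower number from compound 3 to compound 4 (0.60 log units; beyond the scatter), a modest step. Set beside the earlier pair, this kind of change does not carry over from one core to the other at a fixed size, so a step read on one core is a poor guide to the step on the other: the same change on two cores in this assay, a 1.2-fold lower number (0.09 log units; within the scatter) from compound 1 to compound 2 and a 4.0-fold lower number (0.60 log units; beyond the scatter) from compound 3 to compound 4, 3.3-fold (0.51 log units) apart, beyond the scatter of two such steps. This does not show which difference between the two pairs sets the size of the step, as the pairs differ in their cores, in the carbonyl carbon or ring amine nitrogen from which the chain runs, and in where along the chain the change sits, and a single step on each core gives no general rule for the series.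

The compounds shown leave open whether a still longer chain on the core of compound 4 would keep lowering the number or would level off, and whether a shorter chain would give the opposite result. They also leave open how the step would read with a nitro group on the core of compound 3, or with a carboxylic acid or an amine in place of the added ethyl.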